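The compounds below may be only part of what the source reports. "The series", "measured", "known", "first", "only" and "open" are said of these compounds alone.

For the measured compounds named here, in a physicochemical assay for solubility, read by HPLC, in phosphate buffer, measured as thermodynamic solubility (on this read-out lower numbers stand for lower solubility and higher numbers for higher solubility), compound 2 `C/C1=C\C[C@H]2CNC(=O)c3cc([nH]c32)-c2cccc3nc(C)c(nc23)NC1` gives 27000 nM, the only true number among the measured compounds. Compound 1 `Cc1nc2cccc3c2nc1NC/C=C/C[C@H]1CNC(=O)c2cc-3[nH]c21` reports only a limit, < 5000 nM. Compound 3 `Cc1nc2cccc3c2nc1NC/C=C\C[C@H]1CNC(=O)c2cc-3[nH]c21` likewise reports only a limit, < 5000 nM. Compound 4 `C/C1=C/C[C@H]2CNC(=O)c3cc([nH]c32)-c2cccc3nc(C)c(nc23)NC1` is related to compound 2 as follows: the two compounds have the same atoms and bonds and differ only in configuration as drawn: 1 of 2 stereo elements differ; a double bond is drawn E in compound 2 and Z in compound 4. Going by the values given here, only one measured step bears on this change, a step that the two limits leave unreadable from compound 1 to compound 3, which is relevant for (the fact that compounds 1 and 3 differ only in the configuration as drawn). Its size stays hidden by the limit of < 5000 nM in this assay, at which 2 of the 3 values shown sit, so it offers no size or direction to carry over. No shift beyond the scatter is therefore expected in this assay, though the uncertainty is wide. The expected step is a 1.5-fold lower number from compound 2 to compound 4 (0.18 log units; within the scatter). Compound 4 is estimated at 18000 nM, with an expected range of 5000 nM to 60000 nM.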

Compound 4, solubility: 23000 nM
Compound 4: middle estimate off by 1.3-fold (0.11 log units), on the low side; low and high end bracket the measured number.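

In this assay the change of the double bond from E to Z now has a readable size, with a 1.2-fold lower number from compound 2 to compound 4 (0.07 log units; within the scatter) as the whole of it in this pair. The earlier pair with the same change, compound 1 and compound 3, gave only limits of the assay, and its step cannot be read. For the compounds shown here, compound 2 and compound 4 therefore give the first true numbers on both sides of this change. Going by these compounds, it remains open whether the same holds for compound 1 and compound 3, whose limits hide any step. Also open, on these data alone, is whether this step would stay within the scatter with an amine or a carboxylic acid on the shared core.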